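Methylating the Ring Amine of a Potent Serotonin Receptor Binder

The source may report more compounds than this note shows. Statements on the series, on what has been measured and on what is new or still open speak of the compounds shown alone.

Measured compounds:
- Compound 1, `CNc1nc(N2CC[C@H](N)C2)nc2ccc(Cl)cc12`: 2340 nM
- Compound 2, `CN1CCN(c2cc(N)c3ccccc3n2)CC1`: 1.45 nM

Of the compounds shown here, two have been tested in an assay on HEK293 cells for displacement of a labelled ligand from 5-hydroxytryptamine receptor 3A (Homo sapiens), read by scintillation counting, with a stated time of 24 h, in the presence of a further agent that is not named here; a lower number here means a stronger inhibitor, a higher number a weaker inhibitor. Compound 1 gives 2340 nM in this assay, while compound 2 gives 1.45 nM. Of the two numbers, compound 2 holds the lower one by a wide margin, well beyond the usual scatter, so it is the stronger binder of the pair. The two structures differ in several places at once, so the gap between them cannot be tied to any single change.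

Compound 3, `CNc1cc(N2CCN(C)CC2)nc2ccccc12`, differs from compound 2 in one place only: methyl in place of hydrogen on a nitrogen on an aromatic ring. Among the measured compounds shown here, no measured pair in this set shows a change of this kind, so there is no direct guide for its size. Adding a single methyl to an amine that sits on the aromatic core is a small change, and the expectation is a small step, most likely within the scatter, with a slight lean towards a higher number. The expected step from compound 2 to compound 3 is therefore a 2.1-fold higher number from compound 2 to compound 3 (0.32 log units; beyond the scatter). Compound 3 is estimated at 3 nM, within a range of 0.8 nM to 12 nM.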

Compound 3, inhibition constant: 13.5 nM
For compound 3 the middle estimate is 4.5-fold (0.65 log units) below the measured one; measured number outside the range, above it.
By their numbers in this assay, from the lowest: compound 2; then compound 3; then compound 1.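

In this assay, replacing amino with methylamino on the shared core gives a 9.3-fold higher number from compound 2 to compound 3 (0.97 log units; beyond the scatter), so this nitrogen on the aromatic ring is a place where even one added methyl moves the number beyond the usual scatter. The change weakens binding without removing it: compound 3 remains a strong binder at 13.5 nM, which means that a group can be carried on this nitrogen at a real but limited cost. Nothing available here accounts for the size of this step, so the result stands as an observation and not as an explanation.

The compounds shown leave open whether the number keeps rising as the group on this nitrogen grows, for example with an ethyl group, a longer chain, or a second methyl on the same nitrogen. Among the compounds shown here, this is also only one matched pair on one core, so it remains unknown whether the same methyl would cost as much on a different core.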